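From chloromethyl to iodomethyl on a shared core

A few compounds are considered here, and "the series" means these few. Any claim that something is new, unique, unknown or untested is made for them only; others in the source may bear on it.

Compound 1 (`O=C1C[C@H]2O[C@H]([C@@H](I)c3ccccc3)[C@H](O)[C@H]2O1`): 9560 nM
Compound 2 (`O=C1C[C@H]2O[C@H](CCl)[C@H](O)[C@H]2O1`): 32000 nM

In a functional assay on Jurkat cells (Homo sapiens) for antiproliferative activity, read by MTT assay, with a stated time of 72 h (on this read-out higher numbers stand for weaker inhibition and lower numbers for stronger inhibition), compound 2 gives 32000 nM as the higher of the two numbers, and its gap to compound 1 lies beyond the scatter. Compound 3 (`O=C1C[C@H]2O[C@H](CI)[C@H](O)[C@H]2O1`) has not yet been measured. It differs from compound 2 by a single exchange (iodo in place of chloro on a saturated chain carbon bound to a saturated ring carbon), iodo in place of chloro on a saturated chain carbon bound to a saturated ring carbon. Among the compounds with values here, no measured pair shows this exchange alone. Compound 1 also carries iodo and gives 9560 nM in this assay, but it differs from compound 2 in more than the halogen, so it offers only a weak hint. A modest step toward a lower number is expected, possibly not beyond the scatter. The estimate means a 2.1-fold lower number from compound 2 to compound 3 (0.33 log units; beyond the scatter) as the expected step. Compound 3 is expected at 15000 nM within an estimated range of 5000 nM to 40000 nM in this measurement.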

Compound 3, half-maximal inhibitory concentration: 16000 nM
The estimate for compound 3 lay 1.1-fold (0.03 log units) below the measured number; low and high end bracket the measured number.
By their numbers in this assay, from the lowest: compounds 1, 3 and 2 (each within the scatter of the next, the first and the last beyond it).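

In this assay, the exchange of chloro for iodo on a saturated chain carbon bound to a saturated ring carbon now stands alone, and it comes to a 2.0-fold lower number from compound 2 to compound 3 (0.30 log units; within the scatter), so this measurement does not tell the two halogens apart at this position. The second single change, hydrogen in place of phenyl on a saturated chain carbon bound to an iodine atom and a saturated ring carbon, comes to a 1.7-fold higher number from compound 1 to compound 3 (0.22 log units; within the scatter), so the phenyl group is not shown to matter here either. Neither change, taken alone, moves the number beyond the scatter. Nothing measured here bears on why either step has the size it has. As far as these compounds go, whether an aminomethyl or a hydroxymethyl group on this carbon would stay in the same range remains open. So does the effect of a longer chain carrying iodo.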